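The compounds below may be only part of what the source reports. "The series", "measured", "known", "first", "only" and "open" are said of these compounds alone.

Measured in a physicochemical assay for solubility, with a stated time of 24 h, tested at 30 mg/mL; on this read-out higher numbers stand for higher solubility and lower numbers for lower solubility:
- compound 1 `CC(=O)N1CC(CC(=O)NO)(NS(=O)(=O)c2ccc(SCc3cc(C)nc4ccccc34)cc2)C1`: 1000000 nM
- compound 2 `Cc1cc(COc2ccc(S(=O)(=O)NC3(CC(=O)NO)CC3)cc2)c2ccccc2n1`: 1600000 nM
- compound 3 `Cc1cc(COc2ccc(S(=O)(=O)NC3(CC(=O)NO)COC3)cc2)c2ccccc2n1`: 200000 nM

Among these three, compound 3 has the lowest number, 200000 nM. Compound 4 `Cc1cc(COc2ccc(S(=O)(=O)NC3(C(=O)NO)CCCCC3)cc2)c2ccccc2n1` differs from it as follows: a group of 10 heavy atoms (7 carbon, 1 nitrogen, 2 oxygen; one six-membered non-aromatic ring of carbon only) in place of a group of 9 heavy atoms (5 carbon, 1 nitrogen, 3 oxygen; one four-membered non-aromatic ring with 1 hetero atom), on a sulfonamide nitrogen. For the measured compounds named here, only one measured step bears on this change: an 8.0-fold lower number from compound 2 to compound 3 (0.90 log units; beyond the scatter). That step led to the four-membered ring with 1 hetero atom, which compound 4 gives up, so a return towards higher numbers is conceivable. However, no measured compound carries a six-membered ring of carbon only, so this precedent is weak. In this assay, no step beyond the scatter is therefore expected, and the expected step is a 1.3-fold lower number from compound 3 to compound 4 (0.12 log units; within the scatter). For compound 4 the estimated value is 150000 nM, with an expected range of 30000 nM to 800000 nM.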

Compound 4, solubility: 11000000 nM
Estimate against measurement, compound 4: 73-fold (1.87 log units) below; measured number outside the range, above it.
By their numbers in this assay, from the lowest: compound 3; then compounds 1 and 2 (each within the scatter of the next); then compound 4.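

In this assay, compounds 2 and 3 alone showed only a fall at this place on the sulfonamide nitrogen, whereas this position can also raise the number substantially. The six-membered ring of carbon only gives a 55-fold higher number from compound 3 to compound 4 (1.74 log units; beyond the scatter), far more than the fall it reverses, and also a 6.9-fold higher number from compound 2 to compound 4 (0.84 log units; beyond the scatter), so it exceeds the three-membered ring of carbon only as well. Going by these compounds, what a five-membered ring of carbon only or an amine in this group would give remains open. Nothing at hand explains these steps.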